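Carbamate to Urea on a Benzothiazole Core: Cytotoxicity Expected Unchanged

This account rests on a few compounds, and the source may have more. Where it says the series, first, only, none or still open, it means among the compounds named here.

Measured so far:
compound 1 `CC(C)(C)OC(=O)Nc1nc2ccc(NC(=O)c3c(Cl)cccc3Cl)cc2s1` — 0.027 ug/mL
compound 2 `O=C(Nc1nc2ccc(NC(=O)c3c(Cl)cccc3Cl)cc2s1)OCc1ccccc1` — 0.018 ug/mL

In a functional assay on WI-38 VA13 cells (Homo sapiens) for cytotoxicity (a lower number here means that less compound is needed, a higher number that more compound is needed for the effect), compound 2 gives the lowest of the two numbers, though compound 1 lies within the scatter of it, as a 1.5-fold lower number from compound 1 to compound 2 (0.18 log units; within the scatter) shows. Compound 3 `O=C(NCc1ccccc1)Nc1nc2ccc(NC(=O)c3c(Cl)cccc3Cl)cc2s1` carries benzylamino in place of benzyloxy on a carbonyl carbon. For the measured compounds named here, the only measured step swaps the group on the carbamate oxygen and stays within the scatter; no step tests an oxygen replaced by a nitrogen here, so the change is expected to bring no step beyond the scatter, a 1.1-fold higher number from compound 2 to compound 3 (0.05 log units; within the scatter). Compound 3 is therefore estimated at 0.02 ug/mL, between 0.006 ug/mL and 0.07 ug/mL.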

Compound 3, half-maximal effective concentration: 0.15 ug/mL
For compound 3 the middle estimate is 7.5-fold (0.88 log units) below the measured one, outside the stated range (above it).
By their numbers in this assay, from the lowest: compounds 2 and 1 (each within the scatter of the next); then compound 3.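

In this assay the atom linking the carbonyl carbon to the rest of the group matters: benzylamino in place of benzyloxy gives an 8.3-fold higher number from compound 2 to compound 3 (0.92 log units; beyond the scatter) while the earlier change on the oxygen stayed within the scatter. Benzylamino in place of tert-butoxy points the same way, with a 5.6-fold higher number from compound 1 to compound 3 (0.74 log units; beyond the scatter) and both steps beyond the scatter. No available evidence bears on this result. On these data alone, it remains open whether the step follows the added hydrogen-bond donor or the nitrogen itself, a question that a benzyl(methyl)amino group on the same carbonyl carbon could help to separate.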